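A few compounds are considered here, and "the series" means these few. Any claim that something is new, unique, unknown or untested is made for them only; others in the source may bear on it.

Measured compounds:
compound 1, `CC(C)(C)c1cc(CNC(=O)Nc2cccc3[nH]ncc23)n(-c2cccc(Cl)c2)n1`, 0.6 nM
compound 2, `Cn1ncc2c(NC(=O)NCc3cc(C(C)(C)C)nn3-c3cccc(Cl)c3)cccc21`, 0.4 nM

Both numbers come from an assay on CHO-K1 cells for antagonist activity at transient receptor potential cation channel subfamily V member 1 (Homo sapiens), read by FLIPR and calcium flux, with a stated time of 6 min; a lower number here means a stronger inhibitor, a higher number a weaker inhibitor. Among the measured compounds shown here, of the two measured compounds, compound 1 has the higher number, but the only neighbouring step, a 1.5-fold lower number from compound 1 to compound 2 (0.18 log units; within the scatter), is within the scatter, so the two compounds cannot be told apart on these data.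

The unmeasured compound 3, `CC(C)(C)c1cc(CNC(=O)Nc2cccc3[nH]ncc23)n(-c2ccc(F)cc2)n1`, differs from compound 1 by 4-fluorophenyl in place of 3-chlorophenyl on an aromatic nitrogen. For the measured compounds named here, no measured step touches this part of the shared core: the one known step, from compound 1 to compound 2, changes a different aromatic nitrogen and is in any case within the scatter. There is therefore nothing in the data to point to a large shift in either direction in this assay, and only a small step, if any, is expected, a 2.0-fold higher number from compound 1 to compound 3 (0.30 log units; within the scatter). Compound 3 is expected to give about 1.2 nM, within the range 0.4 nM to 5 nM.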

Compound 3, inhibition constant: 2.2 nM
Compound 3: middle estimate off by 1.8-fold (0.26 log units), on the low side, and the stated range covers the measured number.
By their numbers in this assay, from the lowest: compounds 2 and 1 (each within the scatter of the next); then compound 3.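

Placing 4-fluorophenyl where compound 1 has 3-chlorophenyl, on the aromatic nitrogen of the five-membered ring, gives in this assay a 3.7-fold higher number from compound 1 to compound 3 (0.56 log units; beyond the scatter) and so provides the first reading at this position. The step is modest but beyond the scatter, so this position is sensitive to which substituted phenyl it carries, even though both groups have the same heavy-atom count. Both the halogen and its place on the phenyl ring change in this single step, and no measurement here explains the shift.

The compounds shown leave open whether the halogen or its placement matters more, since neither 4-chlorophenyl nor 3-fluorophenyl is among them. They also leave open how this position responds to groups other than substituted phenyl, such as cyclohexyl or a simple methyl.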